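The source may hold more compounds than are shown below. What is called first, only, known or untested is meant among the compounds shown, and "the series" means these compounds.

Measured in an ADME assay on L6 cells (Rattus norvegicus) for cytotoxicity, read by resazurin assay, with a stated time of 72 h; on this read-out lower numbers stand for stronger inhibition and higher numbers for weaker inhibition:
compound 1 `N=C(N)c1ccc(OCc2ccc([N+](=O)[O-])cc2)c(I)c1` gives 10700000 nM
compound 2 `N=C(N)c1cccc(OCc2cccc([N+](=O)[O-])c2)c1` gives 78900000 nM
compound 3 `N=C(N)c1ccc(COc2ccc([N+](=O)[O-])cc2)cc1` gives 79200000 nM

Compound 3 (79200000 nM) and compound 2 (78900000 nM) sit level, within the usual scatter of repeated measurements. Compound 1 (10700000 nM) has a lower number than compound 3, and that gap lies beyond the scatter. Compound 3 therefore stands at the upper end of this small set, in company with compound 2.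

The next compound, compound 4 `CC(C)c1ccc(OCc2ccc(C(=N)N)cc2)cc1`, is compound 3 with one change: isopropyl in place of nitro on an aromatic carbon, para to a large group (isopropyl in place of nitro on an aromatic carbon). Among the measured compounds shown here, no measured pair of compounds differs in one place, so the data show nothing directly about this swap. For the measured compounds named here, the only guide is the spread of the three values, and compound 1 (10700000 nM) shows that a number well under that of compound 3 is possible in this set. A moderate move toward a lower number in this assay is therefore expected, with wide uncertainty.

The estimated change is a 2.6-fold lower number from compound 3 to compound 4 (0.42 log units; beyond the scatter) in this expectation. For compound 4 the expected value is 30000000 nM (estimated range 8000000 nM to 90000000 nM).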

Compound 4, half-maximal inhibitory concentration: 5360000 nM
Compound 4: the middle estimate sits 5.6-fold (0.75 log units) above what was measured; the whole stated range lies above it.
By their numbers in this assay, from the lowest: compounds 4 and 1 (each within the scatter of the next); then compounds 2 and 3 (each within the scatter of the next).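

In this assay, among the compounds shown here, the aromatic carbon para to a large group proves to be a sensitive place: putting isopropyl in place of nitro there gives a 15-fold lower number from compound 3 to compound 4 (1.17 log units; beyond the scatter), the first step in this set that can be tied to a single change. The two groups are the same size by heavy-atom count, with three each, yet they differ in what they carry: nitro brings nitrogen, oxygen and two hydrogen-bond acceptors, whereas isopropyl is carbon only and has no hydrogen-bond acceptors, so a matching heavy-atom count did not keep the number steady. No measurement available here shows what lies behind this large step.

For the compounds shown here, with only one swap at this position, it remains open whether the lower number follows from losing nitro, from gaining isopropyl, or from both, and how other groups there, such as an amine, a carboxylic acid or a longer chain, would compare. From the compounds shown here alone, it is equally open whether the same swap would produce a step of similar size on the cores of compound 1 or compound 2, where the groups are arranged differently.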